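A few compounds are considered here, and "the series" means these few. Any claim that something is new, unique, unknown or untested is made for them only; others in the source may bear on it.

Compound 1 `[O-][n+]1nc(NCCN2CCCCC2)[n+]([O-])c2cc(Cl)ccc21` was tested in a functional assay on HT-29 cells (Homo sapiens) for cytotoxicity, with a stated time of 4 h (on this read-out higher numbers stand for weaker inhibition and lower numbers for stronger inhibition), where compound 1 gives 400 nM. Compound 2 `CCCN(CCC)CCNc1n[n+]([O-])c2ccc(Cl)cc2[n+]1[O-]` carries the change dipropylamino in place of piperidin-1-yl on a saturated chain carbon, two bonds along the chain from a nitrogen on an aromatic ring on the same core, and in this assay compound 2 gives 600 nM; the step of a 1.5-fold higher number from compound 1 to compound 2 (0.18 log units; within the scatter) thus counts as no clear change. Compound 3 `CC(C)(C)c1ccc2c(c1)[n+]([O-])c(NCCN1CCCCC1)n[n+]2[O-]` differs from compound 1 in its core by tert-butyl in place of chloro on an aromatic carbon, and in this assay compound 3 gives 4000 nM, so the step of a 10-fold higher number from compound 1 to compound 3 (1.00 log units; beyond the scatter) is a modest loss of inhibition. Compound 4 `CCCN(CCC)CCNc1n[n+]([O-])c2ccc(C(C)(C)C)cc2[n+]1[O-]` has not yet been tested in this assay. It differs from compound 3 by dipropylamino in place of piperidin-1-yl on a saturated chain carbon, two bonds along the chain from a nitrogen on an aromatic ring, which is the same change as that between compound 1 and compound 2, made at the same place on a core that differs by the tert-butyl for chloro exchange. Since the earlier step of a 1.5-fold higher number from compound 1 to compound 2 (0.18 log units; within the scatter) stayed within the scatter, the step from compound 3 to compound 4 is expected to be small as well, about a 1.5-fold higher number from compound 3 to compound 4 (0.18 log units; within the scatter). Compound 4 is therefore estimated to give about 6000 nM in this assay, with a range of 3000 nM to 12000 nM.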

Compound 4, half-maximal inhibitory concentration: 8300 nM
Estimate against measurement, compound 4: 1.4-fold (0.14 log units) below; measured number inside the range.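

In this assay, dipropylamino in place of piperidin-1-yl on the core carrying tert-butyl gives a 2.1-fold higher number from compound 3 to compound 4 (0.32 log units; beyond the scatter), and this step matches the one seen on the core carrying chloro: the same change on two cores in this assay, a 1.5-fold higher number (0.18 log units; within the scatter) from compound 1 to compound 2 and a 2.1-fold higher number (0.32 log units; beyond the scatter) from compound 3 to compound 4, 1.4-fold (0.14 log units) apart, within the scatter of two such steps. Tert-butyl in place of chloro, read on the compounds carrying dipropylamino, gives a 14-fold higher number from compound 2 to compound 4 (1.14 log units; beyond the scatter), and this step likewise matches its earlier counterpart: the same change on two cores in this assay, a 10-fold higher number (1.00 log units; beyond the scatter) from compound 1 to compound 3 and a 14-fold higher number (1.14 log units; beyond the scatter) from compound 2 to compound 4, 1.4-fold (0.14 log units) apart, within the scatter of two such steps. Each change thus carries over between these cores with its size kept, but this rests on only four compounds and does not show that it would hold on any other core, nor does it explain why either change has the size it has.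

The compounds shown leave open whether another amine at the end of the chain, such as morpholin-4-yl or dimethylamino, or a longer chain would follow the same behaviour. They also leave open how a methoxy group or a plain hydrogen in place of chloro or tert-butyl would combine with these amines.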